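This account rests on a few compounds, and the source may have more. Where it says the series, first, only, none or still open, it means among the compounds named here.

Working notes on the series. The three measured compounds share one core and differ only in the amine on the aromatic ring. In a physicochemical assay for lipophilicity (on this read-out higher numbers stand for higher lipophilicity and lower numbers for lower lipophilicity), compound 1 `CCN(Cc1cccnc1)c1ccc(C(=O)N2CCc3ccc(OS(N)(=O)=O)cc3C2)cc1` gives 1.93; compound 2 `CCN(Cc1ccc(F)cc1)c1ccc(C(=O)N2CCc3ccc(OS(N)(=O)=O)cc3C2)cc1` gives 1.93; compound 3 `CCCN(CCC)c1ccc(C(=O)N2CCc3ccc(OS(N)(=O)=O)cc3C2)cc1` gives 3.07. Compound 2 stands level with compound 1 at the digits shown, the two together the lowest of the three numbers, and the step of no change at the digits printed from compound 1 to compound 2 (within the scatter) lies within the scatter. The steps of a number 1.14 log units higher from compound 2 to compound 3 (beyond the scatter) and a number 1.14 log units higher from compound 1 to compound 3 (beyond the scatter) are large.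

Compound 4 `CCN(Cc1ccccc1)c1ccc(C(=O)N2CCc3ccc(OS(N)(=O)=O)cc3C2)cc1` differs from compound 2 by hydrogen in place of fluoro on an aromatic carbon. Among the measured compounds shown here, no measured step removes a fluoro from an aromatic carbon. For the measured compounds named here, the one step that touches the 4-fluorophenyl, no change at the digits printed from compound 1 to compound 2 (within the scatter), exchanges it for pyridin-3-yl without change, and the large steps to compound 3 concern the whole dipropylamino in place of ethyl(4-fluorobenzyl)amino or ethyl((pyridin-3-yl)methyl)amino. A step no larger than the scatter is therefore expected in this assay, if anything toward a lower number. Compound 4 is expected in this assay at 1.78, between 1.5 and 2.1. The step this estimate implies, a number 0.15 log units lower from compound 2 to compound 4 (within the scatter), is expected to remain within the scatter.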

Compound 4, partition coefficient: 3.08
For compound 4 the middle estimate is 1.30 log units below the measured one, and the stated range ends below it.
By their numbers in this assay, from the lowest: compounds 1 and 2 (each within the scatter of the next); then compounds 3 and 4 (each within the scatter of the next).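

Hydrogen in place of fluoro on an aromatic carbon, para to a large group, is not a neutral exchange in this assay: the change gives (a number 1.15 log units higher from compound 2 to compound 4 (beyond the scatter)), although 4-fluorophenyl and pyridin-3-yl had shown no separation at this place. Phenyl in place of pyridin-3-yl likewise gives (a number 1.15 log units higher from compound 1 to compound 4 (beyond the scatter)), while benzyl(ethyl)amino in place of dipropylamino gives only (a number 0.01 log units higher from compound 3 to compound 4 (within the scatter)), so the result depends on the single fluoro rather than on the amine as a whole. No supporting data bear on the origin of this step.

The compounds shown leave open whether this step is particular to fluoro or also appears with chloro, methyl or methoxy on the same aromatic carbon. They also leave open whether a fluoro elsewhere on the phenyl ring would give a comparable step.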